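From tert-Butyl to Benzyl: What to Expect for Compound 4

A few compounds are considered here, and "the series" means these few. Any claim that something is new, unique, unknown or untested is made for them only; others in the source may bear on it.

Of the compounds shown here, three sharing one core have been measured in a functional assay on HeLa cells (Homo sapiens) for antiproliferative activity, read by resazurin assay; on this read-out higher numbers stand for weaker inhibition and lower numbers for stronger inhibition. Compound 1 `Cc1ccc(C(=O)CSC(=S)SC(C)(C)C)cc1` gives 31600 nM in this assay, the highest number of the three, which makes it the weakest inhibitor of this group. Compound 2 `CCSC(=S)SCC(=O)c1cccc(NC(C)=O)c1` gives 10000 nM and lies nearest to compound 1, while compound 3 `CCSC(=S)SCC(=O)c1ccc(N(CC)CC)cc1` gives 3160 nM and lies furthest away; both gaps are beyond the usual scatter. Compounds 2 and 3 differ from compound 1 in more than one place, so no single structural change can be read from them.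

Compound 4 `Cc1ccc(C(=O)CSC(=S)SCc2ccccc2)cc1` has not yet been measured. It differs from compound 1 in one place: benzyl in place of tert-butyl on a sulfur. The benzyl group brings one six-membered aromatic ring of carbon only to the sulfur whose other neighbour is the thiocarbonyl carbon, where tert-butyl had no ring. Among the measured compounds shown here, none of the measured compounds shows what this exchange does, so the step expected here, a 1.6-fold lower number from compound 1 to compound 4 (0.20 log units; within the scatter), is small and may not exceed the scatter. Compound 4 is expected to give about 20000 nM in this assay, within a range from 6000 nM to 60000 nM.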

Compound 4, half-maximal inhibitory concentration: 25100 nM
For compound 4 the middle estimate is 1.3-fold (0.10 log units) below the measured one; measured number inside the range.
By their numbers in this assay, from the lowest: compound 3; then compound 2; then compounds 4 and 1 (each within the scatter of the next).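

Among the compounds shown here, on the sulfur whose other neighbour is the thiocarbonyl carbon, benzyl in place of tert-butyl gives a 1.3-fold lower number from compound 1 to compound 4 (0.10 log units; within the scatter) in this assay and provides the first single change that can be read in this group of compounds. At this position, then, this assay does not separate a group with one six-membered aromatic ring of carbon only from tert-butyl with no ring, even though benzyl brings more heavy atoms. No supporting measurement bears on what lies behind this result.

Going by these compounds, it remains open whether a different group on this sulfur, such as a longer chain ending in a carboxylic acid or an amine, would shift the number beyond the scatter. On these data alone, it is also open whether the same exchange would give a similarly small step on a compound with a different core.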